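The compounds below may be only part of what the source reports. "The series", "measured", "known", "first", "only" and "open" are said of these compounds alone.

Of the compounds shown here, two with the shared core have been measured so far. Compound 1 `COc1ccc(NC(=O)Nc2cc(C)nc3ccccc23)cc1OC` gives > 25000 nM in an ADME assay on BJ cells (Homo sapiens) for cytotoxicity, with a stated time of 72 h (on this read-out lower numbers stand for an effect already at smaller amounts and higher numbers for an effect only at larger amounts of compound), which is a limit of the assay and not a number. Among the compounds with values here, compound 2 `COC(=O)c1cccc(NC(=O)Nc2cc(C)nc3ccccc23)c1` gives 21000 nM, the only true number, so it stands alone on the scale. Compound 3 `COc1cccc(NC(=O)Nc2cc(C)nc3ccccc23)c1` has not yet been measured. It differs from compound 2 in one place, methoxy in place of methoxycarbonyl on an aromatic carbon, meta to a large group. Within the data shown here, no measured step shows this change directly. The nearest guide is compound 1, which also carries methoxy and belongs to the limit of > 25000 nM in this assay, at which 1 of the 2 values shown sits. The expected change in this assay, a 1.1-fold higher number from compound 2 to compound 3 (0.06 log units; within the scatter), is small and slightly upward, of a size not beyond the usual scatter. For compound 3 the estimated value is 24000 nM, with an expected range from 13000 nM to 40000 nM, and the reading may well come back only as a limit.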

Compound 3, half-maximal effective concentration: 27000 nM
The estimate for compound 3 lay 1.1-fold (0.05 log units) below the measured number, and the stated range covers the measured number.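

In this assay, methoxy in place of methoxycarbonyl on an aromatic carbon, meta to a large group, gives a 1.3-fold higher number from compound 2 to compound 3 (0.11 log units; within the scatter), so this position now has a directly measured step, and this exchange of groups stays within the usual scatter. Compound 3 also gives the series a second true number, which means that two different groups at this position now have readable values that cannot be told apart. Compound 1 stands at a limit of the assay and not at a number, so the step from it to compound 3 cannot be read: the limit of > 25000 nM in this assay, at which 1 of the 3 values shown sits.

As far as these compounds go, whether an amine, a carboxylic acid or a longer chain on this aromatic carbon would move the reading in this assay beyond the scatter stays open, since the two groups with readable values span only a narrow stretch of the scale. Also open, from the compounds shown here alone, is whether the exchange of methoxycarbonyl for methoxy would give an equally small step on a ring that carries a further methoxy, as the ring of compound 1 does.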